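The source may report more compounds than this note shows. Statements on the series, on what has been measured and on what is new or still open speak of the compounds shown alone.

Compound 2 `O=C(Nc1cc(-c2ccccc2)nn1-c1ccccc1)c1ccccc1Cl` carries a 2-chlorophenyl on the carbonyl carbon of the shared core and gives 2500 nM in an assay on CHO cells with metabotropic glutamate receptor 5 (Homo sapiens) as the target (on this read-out higher numbers stand for an effect only at larger amounts of compound and lower numbers for an effect already at smaller amounts), the higher of the two numbers recorded. Its nearest neighbour is compound 1 `Cc1ccc(C(=O)Nc2cc(-c3ccccc3)nn2-c2ccccc2)cc1`, which gives 30 nM in this assay. Among the measured compounds shown here, the single measured step, an 83-fold higher number from compound 1 to compound 2 (1.92 log units; beyond the scatter), shows that exchanging the ring on the carbonyl carbon can move this read-out far beyond the scatter. Compound 3 `O=C(Nc1cc(-c2ccccc2)nn1-c1ccccc1)c1ccsc1` differs from compound 2 by thiophen-3-yl in place of 2-chlorophenyl on a carbonyl carbon. For the measured compounds named here, no measured step covers a thiophen-3-yl in this position, so the direction of the change must rest on the one step recorded: it suggests that the ring on the carbonyl carbon is decisive, and a group without the chlorine may read more like compound 1. Compound 3 is therefore expected to give 150 nM, within 25 nM to 900 nM, which would be a step of a 17-fold lower number from compound 2 to compound 3 (1.22 log units; beyond the scatter).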

Compound 3, half-maximal effective concentration: 1800 nM
Beside the measured number, compound 3's estimate is 12-fold (1.08 log units) below it, and the stated range ends below it.
By their numbers in this assay, from the lowest: compound 1; then compounds 3 and 2 (each within the scatter of the next).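

The earlier step left open whether the chlorine alone set compound 2 apart, but a ring without chlorine does not restore the low number of compound 1. In this assay, the step of a 1.4-fold lower number from compound 2 to compound 3 (0.14 log units; within the scatter) leaves thiophen-3-yl and 2-chlorophenyl on the carbonyl carbon indistinguishable, whereas a 60-fold higher number from compound 1 to compound 3 (1.78 log units; beyond the scatter) sets 4-methylphenyl apart from thiophen-3-yl, as it was from 2-chlorophenyl. Among these three rings, only the 4-methylphenyl of compound 1 gives the low number, and no measured evidence explains why.

The compounds shown leave open how a plain phenyl, a 4-chlorophenyl or a 4-aminophenyl on the carbonyl carbon would read. It therefore remains unresolved whether the methyl group or the six-membered ring carrying it separates compound 1 from compound 3.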